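Double bond geometry on the longer acid chain

The source may hold more compounds than are shown below. What is called first, only, known or untested is meant among the compounds shown, and "the series" means these compounds.

In a functional assay for inhibition, with Homo sapiens as the target (on this read-out lower numbers stand for stronger inhibition and higher numbers for weaker inhibition), compound 1 `O=C(O)CCc1c(-c2cccnc2)ccc2c1CCC(NS(=O)(=O)c1ccc(Cl)cc1)C2` gives 140 nM and compound 2 `O=C(O)CCc1cc(Cc2cccnc2)cc2c1CCC(NS(=O)(=O)c1ccc(Cl)cc1)C2` gives 7 nM. Compound 3 `O=C(O)CCC/C=C/c1cc(Cc2cccnc2)cc2c1CCC(NS(=O)(=O)c1ccc(Cl)cc1)C2` gives 1200 nM, the highest of the three numbers, with compound 1 its nearest neighbour and compound 2 its furthest.

Compound 4 `O=C(O)CCC/C=C\c1cc(Cc2cccnc2)cc2c1CCC(NS(=O)(=O)c1ccc(Cl)cc1)C2` is the next comparison: the two compounds have the same atoms and bonds; at least one stereo element is drawn with a configuration in one of them and without one in the other: 1 of 2 stereo elements differ; a double bond is drawn E in compound 3 and Z in compound 4. The two compounds have the same atoms and bonds, and the double bond is drawn E in compound 3 and Z in compound 4.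

Among the compounds with values here, only one measured step bears on this change, and only indirectly. Placing 5-carboxypent-1-en-1-yl in place of 2-carboxyethyl gave a large rise, a 170-fold higher number from compound 2 to compound 3 (2.23 log units; beyond the scatter). Within the data shown here, this shows that the number responds strongly to this chain, but no measured pair tests the double bond geometry alone. A moderate step towards a lower number is expected, with its direction weakly supported and a full return to the level of compound 2 not expected.

The estimated change is a 2.4-fold lower number from compound 3 to compound 4 (0.38 log units; beyond the scatter).

For compound 4, the expected value is 500 nM, with an estimated range of 60 nM to 3000 nM.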

Compound 4, half-maximal inhibitory concentration: 90 nM
For compound 4 the middle estimate is 5.6-fold (0.74 log units) above the measured one; low and high end bracket the measured number.
By their numbers in this assay, from the lowest: compound 2; then compounds 4 and 1 (each within the scatter of the next); then compound 3.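

In this assay the double bond geometry on the 5-carboxypent-1-en-1-yl chain moves the number by itself, a 13-fold lower number from compound 3 to compound 4 (1.12 log units; beyond the scatter), so the large change seen at this position cannot be assigned to the chain alone. The Z chain still does not reach the level of the 2-carboxyethyl chain, a 13-fold higher number from compound 2 to compound 4 (1.11 log units; beyond the scatter), so only part of the gap from compound 2 to compound 3 is tied to the E form. One point qualifies this reading of the geometry: the fact that one of compounds 3 and 4 is drawn with a defined configuration and the other without, at the place where they differ.

Open, going by these compounds, is how a saturated 5-carboxypentyl chain would compare with compound 3 and compound 4, a comparison that would separate chain length from the double bond. Also open, on these data alone, is where a 3-carboxypropyl chain would fall relative to compound 2.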